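The source may report more compounds than this note shows. Statements on the series, on what has been measured and on what is new or still open speak of the compounds shown alone.

Measured so far:
Compound 1, `CN1CCc2nc(C#Cc3ccccc3)sc2C1` — in an assay on HEK293 cells for positive allosteric modulation of metabotropic glutamate receptor 5 (Homo sapiens), read by FLIPR, with a stated time of 1 h (a higher number here means that more compound is needed for the effect, a lower number that less compound is needed), compound 1 gives 34 nM
Compound 2, `COC1CC(C(=O)N2CCc3nc(C#Cc4ccccc4)sc3C2)C1` — in this assay compound 2 gives 640 nM

Of these two numbers, compound 2 holds the higher one, meaning more of it is needed for the effect. Going by the values given here, its only neighbour is compound 1, and the step between them, a 19-fold higher number from compound 1 to compound 2 (1.27 log units; beyond the scatter), came from putting a (3-methoxycyclobutyl)carbonyl in place of a methyl on the amine nitrogen in the ring.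

Compound 3, `O=C(C1CCCC1)N1CCc2nc(C#Cc3ccccc3)sc2C1`, differs from compound 2 by cyclopentyl in place of 3-methoxycyclobutyl on a carbonyl carbon. Among the compounds with values here, the one measured step compares a bare methyl with a carbonyl-bearing group; it does not compare one ring on the carbonyl with another, so it speaks only loosely to this change. Compound 2 and compound 3 both keep the carbonyl on the ring nitrogen, and the change is confined to the ring beyond it. With no measured guide for that kind of swap, the expectation is a step no larger than the usual scatter, a 1.3-fold lower number from compound 2 to compound 3 (0.11 log units; within the scatter). Compound 3 is therefore estimated at 500 nM, within a range of 180 nM to 1500 nM.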

Compound 3, half-maximal effective concentration: 19 nM
The estimate for compound 3 lay 26-fold (1.42 log units) above the measured number, outside the stated range (below it).
By their numbers in this assay, from the lowest: compounds 3 and 1 (each within the scatter of the next); then compound 2.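

Going by these compounds alone, the ring on the carbonyl carbon turns out to matter far more than the one earlier step could show: cyclopentyl in place of 3-methoxycyclobutyl gives a 34-fold lower number from compound 2 to compound 3 (1.53 log units; beyond the scatter) in this assay with nothing else in the molecule changed. The earlier step could be read as a heavy cost for any carbonyl group placed on the amine nitrogen in the ring, but cyclopentylcarbonyl in place of methyl gives only a 1.8-fold lower number from compound 1 to compound 3 (0.25 log units; within the scatter) and so stays level with the methyl compound. The loss seen with compound 2 therefore belongs to the 3-methoxycyclobutyl group in particular and not to the carbonyl as such, though no measurement here explains it.

This swap changes the four-membered ring to a five-membered one and removes the methoxy group at the same time, so the compounds shown cannot separate those two changes. On these data alone, a plain cyclobutyl on the carbonyl carbon would pull them apart, and how a cyclohexyl or an open chain such as butyl would read there remains open.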